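The source may report more compounds than this note shows. Statements on the series, on what has been measured and on what is new or still open speak of the compounds shown alone.

Measured in an ADME assay on L02 cells (Homo sapiens) for cytotoxicity, read by MTT assay, with a stated time of 24 h; on this read-out higher numbers stand for weaker inhibition and lower numbers for stronger inhibition:

Compound 1 `CN1C/C(=C\c2cccnc2)C(=O)/C(=C/c2ccccc2F)C1`: 15900 nM
Compound 2 `CN1C/C(=C\c2cccnc2)C(=O)/C(=C/c2cc([N+](=O)[O-])ccc2F)C1`: 15700 nM
Compound 3 `CN1C/C(=C\c2ccncc2)C(=O)/C(=C/c2ccccc2F)C1`: 14900 nM

The three compounds cannot be told apart on these numbers. Compound 3, at 14900 nM, lies within the usual scatter of both compound 1 and compound 2, so it stands level with them.

The next compound is compound 4 `CN1C/C(=C\c2ccncc2)C(=O)/C(=C/c2cc([N+](=O)[O-])ccc2F)C1`, which has not yet been measured. It differs from compound 3 by nitro in place of hydrogen on an aromatic carbon, para to a fluoro group and meta to a large group.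

The same replacement has been measured once, in the pyridin-3-yl series, where it gave a 1.0-fold lower number from compound 1 to compound 2 (0.01 log units; within the scatter). The other measured step, pyridin-4-yl in place of pyridin-3-yl, gave a 1.1-fold lower number from compound 1 to compound 3 (0.03 log units; within the scatter). Among the measured compounds shown here, neither change moved the number beyond the scatter, although the two have not yet been seen together in one compound, and that combination is what compound 4 tests. The evidence is thin, resting on a single precedent for the nitro replacement, but it points to no real shift in this assay.

The expected change is a 1.0-fold lower number from compound 3 to compound 4 (0.00 log units; within the scatter), which means no step beyond the scatter in either direction. For compound 4 the estimated value is 14800 nM, with an expected range of 9000 nM to 24000 nM.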

Compound 4, half-maximal inhibitory concentration: 17600 nM
Compound 4: middle estimate off by 1.2-fold (0.08 log units), on the low side, and the stated range covers the measured number.
By their numbers in this assay, from the lowest: compounds 3, 2, 1 and 4 (each within the scatter of the next).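

With compound 4, the nitro replacement can be read on a second core in this assay, where it gives a 1.2-fold higher number from compound 3 to compound 4 (0.07 log units; within the scatter), so the absence of a step beyond the scatter is no longer confined to the pyridin-3-yl series: the same change on two cores in this assay, a 1.0-fold lower number (0.01 log units; within the scatter) from compound 1 to compound 2 and a 1.2-fold higher number (0.07 log units; within the scatter) from compound 3 to compound 4, 1.2-fold (0.08 log units) apart, within the scatter of two such steps. The change from pyridin-3-yl to pyridin-4-yl can now also be read with the nitro group present, where it gives a 1.1-fold higher number from compound 2 to compound 4 (0.05 log units; within the scatter), and the earlier result is likewise repeated on this second core: the same change on two cores in this assay, a 1.1-fold lower number (0.03 log units; within the scatter) from compound 1 to compound 3 and a 1.1-fold higher number (0.05 log units; within the scatter) from compound 2 to compound 4, 1.2-fold (0.08 log units) apart, within the scatter of two such steps. Among the compounds shown here, compound 4 is the only compound that carries both changes, and it stands level with the other three compounds, so in this set neither change alters the outcome of the other beyond the scatter.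

The compounds shown leave open whether another group on this aromatic carbon, such as an amine or a carboxylic acid, would give a step beyond the scatter. They also leave open whether a pyridin-2-yl group in place of pyridin-3-yl, or a hydrogen in place of the fluoro group, would stay level with these four compounds.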